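The source may hold more compounds than are shown below. What is called first, only, known or untested is meant among the compounds shown, and "the series" means these compounds.

In an ADME assay on A549 cells (Homo sapiens) for cytotoxicity, read by resazurin assay, with a stated time of 48 h (on this read-out lower numbers stand for higher toxicity in this test and higher numbers for lower toxicity in this test), compound 1 `CN(C)c1ccc(NC(=O)c2cc(Cl)ccc2O)c(Cl)c1` gives 85100 nM and compound 2 `O=C(Nc1ccc(NCc2ccc(Br)cc2)cc1Cl)c1cc(Cl)ccc1O` gives 40900 nM while compound 3 `O=C(Nc1ccc(NCc2cc(F)cc(Cl)c2)cc1Cl)c1cc(Cl)ccc1O` gives 11100 nM as the lowest of the three numbers. The unmeasured compound 4 `O=C(Nc1ccc(NCc2ccncc2)cc1Cl)c1cc(Cl)ccc1O` differs from compound 3 by pyridin-4-yl in place of 3-chloro-5-fluorophenyl on a saturated chain carbon bound to a nitrogen on an aromatic ring and this takes 3-chloro-5-fluorobenzyl to (pyridin-4-yl)methyl. The measured step at this place is a 3.7-fold lower number from compound 2 to compound 3 (0.57 log units; beyond the scatter) and the other step bearing on it is a 2.1-fold lower number from compound 1 to compound 2 (0.32 log units; beyond the scatter) and both are modest. Neither step puts a ring with a hetero atom here, so the expectation is loose. The expected change is a 3.6-fold higher number from compound 3 to compound 4 (0.56 log units; beyond the scatter) in this assay as a modest step beyond the scatter. Compound 4 is estimated at 40000 nM with 16000 nM to 100000 nM as the expected range.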

Compound 4, half-maximal cytotoxic concentration: 65300 nM
The estimate for compound 4 lay 1.6-fold (0.21 log units) below the measured number; measured number inside the range.
By their numbers in this assay, from the lowest: compound 3; then compounds 2, 4 and 1 (each within the scatter of the next, the first and the last beyond it).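

In this assay, among the compounds shown here, pyridin-4-yl is the first ring with a hetero atom at this place, and it gives a 5.9-fold higher number from compound 3 to compound 4 (0.77 log units; beyond the scatter), so the low number seen with 3-chloro-5-fluorophenyl does not carry over to this ring. The replacement of 4-bromophenyl gives a 1.6-fold higher number from compound 2 to compound 4 (0.20 log units; within the scatter), and the replacement of dimethylamino on an aromatic carbon gives a 1.3-fold lower number from compound 1 to compound 4 (0.12 log units; within the scatter). Nothing available explains these differences.

From the compounds shown here alone, how an unsubstituted phenyl or a piperidin-4-yl would read at this place stays open. Also open, going by these compounds, is whether the low number of compound 3 needs both its chlorine and its fluorine or only one of them.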